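The source may hold more compounds than are shown below. What is called first, only, known or untested is meant among the compounds shown, and "the series" means these compounds.

In a functional assay on the whole organism (brain) with Mus musculus as the target (on this read-out lower numbers stand for an effect already at smaller amounts and higher numbers for an effect only at larger amounts of compound), compound 1 (`O=[N+]([O-])c1ccc(OCCc2c[nH]cn2)cc1`) gives 0.66 mg/kg and compound 3 (`CC(=O)c1ccc(OCCc2c[nH]cn2)cc1`) gives 3.2 mg/kg as the higher of the two actual numbers. Compound 2 (`COC(=O)c1ccc(OCCc2c[nH]cn2)cc1`) is reported only as a limit of > 3 mg/kg in this series. Compound 4 (`CCC(=O)c1ccc(OCCc2c[nH]cn2)cc1`) differs from compound 3 by methyl in place of hydrogen on a saturated chain carbon bound to a carbonyl carbon with methyl in place of hydrogen on a saturated chain carbon bound to a carbonyl carbon, so acetyl becomes propanoyl. The measured steps with readable sizes are a 4.8-fold higher number from compound 1 to compound 3 (0.69 log units; beyond the scatter) and an at least 4.5-fold higher number from compound 1 to compound 2 (0.65 log units; beyond the scatter) but both replace nitro, so neither sizes this change directly. The remaining step is a step that the limit leaves unreadable from compound 2 to compound 3 with no size to offer. No step beyond the scatter is therefore expected, and no firm direction. The expected step is a 1.1-fold higher number from compound 3 to compound 4 (0.04 log units; within the scatter) on this evidence. Compound 4 is estimated at 3.5 mg/kg with an expected range from 1.5 mg/kg to 8 mg/kg in this assay for now.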

Compound 4, dose for half-maximal effect: 0.95 mg/kg
The estimate for compound 4 lay 3.7-fold (0.57 log units) above the measured number, and the stated range ends above it.
By their numbers in this assay, from the lowest: compounds 1 and 4 (each within the scatter of the next); then compound 3.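

In this assay, the position on the saturated chain carbon bound to the carbonyl carbon responds to a single added methyl, which gives a 3.4-fold lower number from compound 3 to compound 4 (0.53 log units; beyond the scatter), and propanoyl does not stand apart from nitro, with a 1.4-fold higher number from compound 1 to compound 4 (0.16 log units; within the scatter). On the carbonyl carbon, ethyl in place of methoxy gives an at least 3.1-fold lower number from compound 2 to compound 4 (0.49 log units; beyond the scatter). That step rests on a limit for compound 2, not on a number: the limit of > 3 mg/kg in this assay, at which 1 of the 4 values shown sits.

From the compounds shown here alone, whether a longer chain, such as butanoyl, would lower the number further or raise it again stays open. So does the effect of an amine at the end of that chain.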